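A few compounds are considered here, and "the series" means these few. Any claim that something is new, unique, unknown or untested is made for them only; others in the source may bear on it.

Two amides of the shared core have a number in a functional assay on the whole organism (strain Icem-CET (SPF Caw)) for inhibition, with Mus musculus as the target, with a stated time of 30 min; a higher number here means that more compound is needed for the effect, a lower number that less compound is needed. Compound 1 `C/C(C(=O)NC1CC1)=C(\C)c1ccc(Br)cc1` gives 52.4 mg/kg there. Compound 2 `C#CCNC(=O)/C(C)=C(\C)c1ccc(Br)cc1` gives 18.4 mg/kg in this assay, the lower of the two numbers; the number for compound 1 sits higher by a margin beyond the scatter. Compound 3 `C=CCNC(=O)/C(C)=C(\C)c1ccc(Br)cc1` has not yet been measured in this assay. It differs from compound 2 by vinyl in place of ethynyl on a saturated chain carbon bound to an amide-type nitrogen, the same difference read one bond further out as propargyl to allyl. Among the compounds with values here, no measured pair shows this change, so the size of the step has no precedent among the measured compounds. Since the change leaves the amide, the core and the aryl bromide untouched, the step from compound 2 to compound 3 is expected to stay within the scatter, a 1.3-fold higher number from compound 2 to compound 3 (0.10 log units; within the scatter), with a slight drift upward if anything. Compound 3 is therefore estimated at 23 mg/kg in this assay, within a range from 9 mg/kg to 55 mg/kg.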

Compound 3, dose for half-maximal effect: 33.7 mg/kg
For compound 3 the middle estimate is 1.5-fold (0.17 log units) below the measured one, within the range that was stated.
By their numbers in this assay, from the lowest: compounds 2, 3 and 1 (each within the scatter of the next, the first and the last beyond it).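

In this assay, within the data shown here, vinyl in place of ethynyl on a saturated chain carbon bound to an amide-type nitrogen gives a 1.8-fold higher number from compound 2 to compound 3 (0.26 log units; within the scatter) and this is the only measured pair at this position. In this pair the propargyl to allyl change stays within the scatter, so the triple bond is not needed to keep the number in this range, and a double bond serves in its place. Nothing measured here accounts for the size of this step.

As far as these compounds go, whether a saturated propyl chain, with neither triple nor double bond, also stays within the scatter of compound 2 remains open. So does the outcome for a longer chain such as butyl, or for a chain ending in an amine or a carboxylic acid.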